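From Methoxy to Hydroxy: Expected Cytotoxicity of Compound 3

The compounds below may be only part of what the source reports. "The series", "measured", "known", "first", "only" and "open" are said of these compounds alone.

Of the compounds shown here, two have been measured in a functional assay on SK-MEL-5 cells (Homo sapiens) for cytotoxicity, read by sulforhodamine B assay, with a stated time of 48 h, tested at 0.01 uM; on this read-out higher numbers stand for a weaker effect at the one concentration tested and lower numbers for a stronger effect. Compound 1 `COc1cc(C)cc(-c2c(-c3ccnc(-c4ccc(N(C)C)cc4)c3)cnn2CC#N)c1` gives 19% in this assay, a strong effect at the single concentration used. Among the measured compounds shown here, compound 2 `COc1cc(C)cc(-c2nn(CC#N)cc2-c2ccnc(-c3ccc(N(C)C)cc3)c2)c1` gives 104% in this assay, the highest of the two numbers, which means the weakest effect; its only neighbour, compound 1, stands far lower, a gap well beyond the scatter of repeated measurements. For the measured compounds named here, no step between two measured compounds that differ in just one place is available, so the size of any single change can only be expected, not read off.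

Compound 3 `Cc1cc(O)cc(-c2nn(CC#N)cc2-c2ccnc(-c3ccc(N(C)C)cc3)c2)c1` is the compound not yet measured. It differs from compound 2 by hydrogen in place of methyl on an oxygen on an aromatic ring. With compound 2 already at the weak end of the scale, the step expected a number 9 percentage points lower from compound 2 to compound 3 (within the scatter) is small, leaning toward a slightly stronger effect, and may well stay within the scatter. Compound 3 is accordingly expected to give about 95% in this assay, estimated to lie between 70% and 110%.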

Compound 3, a percentage reported as activity, at one concentration (the size of the read-out at that concentration, not a potency): 90%
For compound 3 the middle estimate is 5 percentage points above the measured one; low and high end bracket the measured number.
By their numbers in this assay, from the lowest: compound 1; then compound 3; then compound 2.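

In this assay, among the compounds shown here, the change from methoxy to hydroxy on the 3-methoxy-5-methylphenyl group provides the first single-place comparison, a number 14 percentage points lower from compound 2 to compound 3 (beyond the scatter). The step is modest but lies beyond the scatter, showing that this oxygen substituent can shift the read-out and that removing the methyl moves it toward a stronger effect, although compound 3 at 90% remains near the weak end of the scale at the one concentration tested. The pair shows the direction and size of this one change, but the information available offers no measured account of why the number moves.

What the compounds shown leave open is whether another group on that oxygen, such as an ethyl group or a longer chain, or an amine in place of the hydroxy group, would carry the read-out further in the same direction. For the compounds shown here, they also leave open whether the same change from methoxy to hydroxy would produce a comparable step on the core of compound 1, which stands at 19%, since only one such pair can be read here.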